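Compound 3 and the limit in the cytotoxicity assay

This account rests on a few compounds, and the source may have more. Where it says the series, first, only, none or still open, it means among the compounds named here.

Measured in a functional assay on HEK293 cells (Homo sapiens) for cytotoxicity; a lower number here means that less compound is tolerated, a higher number that more compound is tolerated:
compound 1 `COc1ccc([C@H]2CC(=O)N(c3ccccc3N)C2)cc1OC1CCCC1`: > 10000 nM (a limit)
compound 2 `COc1ccc([C@H]2CC(=O)N(c3cccc(C)c3)C2)cc1OC1CCCC1`: > 10000 nM (a limit)

In this assay compound 2 gives > 10000 nM, which is a limit and not a number. Among the compounds with values here, compound 1 also stands at a limit, so no compound here has a numerical value yet. Compound 3 `COc1ccc([C@H]2CC(=O)N(c3ccccc3C(F)(F)F)C2)cc1OC1CCCC1` differs from compound 2 by one change, (2-(trifluoromethyl)phenyl in place of 3-methylphenyl on an amide-type nitrogen in a ring), with 2-(trifluoromethyl)phenyl in place of 3-methylphenyl on the amide-type nitrogen in a ring. Within the data shown here, the one measured step that bears on it, also a change at that nitrogen, is a step that the two limits leave unreadable from compound 1 to compound 2. Among the measured compounds shown here, its size cannot be read, and the only evidence on it is the limit of > 10000 nM in this assay, at which 2 of the 2 values shown sit. No step beyond the scatter is therefore expected in this assay, in either direction. The estimated move is a step that the limit leaves unreadable from compound 2 to compound 3. For compound 3 the expected value is 15000 nM, with an estimated range from 7000 nM to 40000 nM.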

Compound 3, half-maximal cytotoxic concentration: > 10000 nM
Compound 3: a limit, no number; the forecaster's own chance of this, stated with the estimate: 85%; the middle value lies beyond the limit too.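

In this assay compound 3 gives > 10000 nM, which is a limit and not a number. Within the data shown here, no step among compound 1, compound 2 and compound 3 can therefore be read. The compounds shown leave open whether any of these groups on the amide-type nitrogen changes the concentration tolerated: the limit of > 10000 nM in this assay, at which 3 of the 3 values shown sit.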